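Carbonyl-aryl swap in the indole hydroxamate series

The source may report more compounds than this note shows. Statements on the series, on what has been measured and on what is new or still open speak of the compounds shown alone.

Two compounds carry numbers in an assay on isolated protein for inhibition of protein deacetylase HDAC6 (Homo sapiens); on this read-out higher numbers stand for weaker inhibition and lower numbers for stronger inhibition. Compound 1 `COc1ccc(C(=O)c2ccc3c(ccn3S(=O)(=O)c3ccc(/C=C/C(=O)NO)cc3)c2)cc1` gives 848 nM. Compound 2 `COc1ccc(C(=O)c2ccc3c(ccn3Cc3ccc(C(=O)NO)cc3)c2)cc1OC` gives 15.5 nM, the lowest of the two numbers, and the gap from compound 1 to compound 2 lies beyond the usual scatter; the two differ in more than one place, so only the two values themselves are informative.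

Compound 3 `O=C(NO)c1ccc(Cn2ccc3cc(C(=O)c4ccc(Cl)cc4)ccc32)cc1` is unmeasured and differs from compound 2 by a single change: 4-chlorophenyl in place of 3,4-dimethoxyphenyl on a carbonyl carbon. Among the compounds with values here, no measured pair in this set isolates this change, so no reference step exists for it.

The expectation for compound 3 is a step of a 1.4-fold higher number from compound 2 to compound 3 (0.15 log units; within the scatter), small and within or only just beyond the scatter, in no firm direction. Compound 3 is estimated at 22 nM, with a range from 7 nM to 70 nM, in this assay.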

Compound 3, half-maximal inhibitory concentration: 6.73 nM
Compound 3: middle estimate off by 3.3-fold (0.51 log units), on the high side; the measured number lies below the stated range.
By their numbers in this assay, from the lowest: compound 3; then compound 2; then compound 1.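

Placing 4-chlorophenyl in place of 3,4-dimethoxyphenyl on a carbonyl carbon gives a 2.3-fold lower number from compound 2 to compound 3 (0.36 log units; beyond the scatter) in this assay and this modest step is the only single-place comparison in the series. It shows that the methoxy groups of compound 2 are not required for inhibition in this assay: the entering group has fewer heavy atoms and no hydrogen-bond acceptors, yet the number is lower. No measurement at hand accounts for the step.

Still open, as far as these compounds go, is whether the chlorine matters or only the loss of the methoxy groups, a question that plain phenyl, 4-fluorophenyl or 4-methoxyphenyl on the same carbonyl carbon would separate. Also open, from the compounds shown here alone, is whether the same swap gives a similar step on the core of compound 1, which differs from compound 2 in more than one place.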